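The source may hold more compounds than are shown below. What is called first, only, known or untested is meant among the compounds shown, and "the series" means these compounds.

Compound 1 `CCn1c(-c2cnc(C)nc2)nc2c(O[C@H]3CCN(C(=O)C4CC4)C3)ncnc21`: 2.8 L/kg
Compound 2 `CCn1c(-c2ccc(C(F)(F)F)nc2)nc2c(O[C@H]3CCN(C(=O)c4cocn4)C3)ncnc21`: 2.6 L/kg
Compound 3 `CCn1c(-c2ccc(C(F)(F)F)nc2)nc2c(O[C@H]3CCN(C(=O)N4CC(OC)C4)C3)ncnc21`: 4.2 L/kg

In an ADME assay (Rattus norvegicus, strain Wistar Han) for pharmacokinetics (on this read-out lower numbers stand for narrower distribution and higher numbers for wider distribution into tissues), compound 3 gives the highest of the three numbers, yet compound 1 and compound 2 both lie within the usual scatter of it, so no real ordering can be drawn. Compound 4 `CCn1c(-c2ccc(C(F)(F)F)nc2)nc2c(O[C@H]3CCN(C(=O)[C@H]4C[C@@H](OC)C4)C3)ncnc21` differs from compound 3 by 3-methoxycyclobutyl in place of 3-methoxyazetidin-1-yl on a carbonyl carbon. Among the measured compounds shown here, the only measured step at the same place on the carbonyl carbon, a 1.6-fold higher number from compound 2 to compound 3 (0.21 log units; within the scatter), stayed within the scatter, and no measured step exchanges the ring itself in this way. No shift beyond the scatter is therefore expected, and no change at the digits printed from compound 3 to compound 4 (within the scatter) is the estimated change. Compound 4 is expected to give 4.2 L/kg, with a range from 2.4 L/kg to 7 L/kg.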

Compound 4, volume of distribution: 1.3 L/kg
The estimate for compound 4 lay 3.2-fold (0.51 log units) above the measured number; the whole stated range lies above it.
By their numbers in this assay, from the lowest: compounds 4, 2, 1 and 3 (each within the scatter of the next, the first and the last beyond it).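

In this assay, a 3.2-fold lower number from compound 3 to compound 4 (0.51 log units; beyond the scatter) shows that a change on this carbonyl carbon can move the number beyond the scatter, which the earlier step here did not do. The two four-membered rings both carry a methoxy group, and the ring nitrogen of 3-methoxyazetidin-1-yl gives way to carbon in 3-methoxycyclobutyl, whereas a 2.0-fold lower number from compound 2 to compound 4 (0.30 log units; within the scatter) stays within the scatter. No measurement shown accounts for the lower number.

On these data alone, whether a piperidin-1-yl ring or an open methoxyethyl chain on this carbonyl carbon would give a number like that of compound 3 or compound 4 remains open. So does the effect of the opposite arrangement at the two defined stereocentres of 3-methoxycyclobutyl.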